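Swapping the thiophene on an imidazole-bearing scaffold

A few compounds are considered here, and "the series" means these few. Any claim that something is new, unique, unknown or untested is made for them only; others in the source may bear on it.

Of the compounds shown here, two have been measured in an assay for inhibition of steroid 17-alpha-hydroxylase/17,20 lyase (Homo sapiens), using NADPH, tested at 0.2 uM; on this read-out lower numbers stand for a weaker effect and higher numbers for a stronger effect at the one concentration tested. Compound 1, with the structure `CSc1ccc(-c2ccc(Cn3ccnc3)cc2)s1`, gives 3% in this assay. Compound 2, with the structure `CCC(c1ccc(-c2ccsc2)cc1)n1ccnc1`, gives 28% in this assay, the higher of the two numbers and a gap to compound 1 that lies beyond the usual scatter.

Compound 3, with the structure `CCC(c1ccc(-c2ccc(SC)s2)cc1)n1ccnc1`, has not yet been measured. It differs from compound 2 in a single place: 5-(methylsulfanyl)thiophen-2-yl in place of thiophen-3-yl on an aromatic carbon. Among the compounds with values here, no measured pair shows exactly this change, so its effect is not known from the data at hand. Compound 1 carries the same entering group but on a different core, so it offers only a loose hint.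

For compound 3, the expected outcome in this assay is 22%, with a range from 5% to 45%. The expected step of a number 6 percentage points lower from compound 2 to compound 3 (within the scatter) is small, likely within the scatter or slightly downward.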

Compound 3, a percentage reported as inhibition, at one concentration (the size of the read-out at that concentration, not a potency): 2%
The estimate for compound 3 lay 20 percentage points above the measured number; the measured number lies below the stated range.
By their numbers in this assay, from the lowest: compounds 3 and 1 (each within the scatter of the next); then compound 2.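

In this assay, 5-(methylsulfanyl)thiophen-2-yl in place of thiophen-3-yl on the aromatic carbon gives a number 26 percentage points lower from compound 2 to compound 3 (beyond the scatter), so on this core the position does not tolerate this change without losing most of the read-out. With the new group in place, ethyl in place of hydrogen on the saturated chain carbon gives a number 1 percentage points lower from compound 1 to compound 3 (within the scatter), so the ethyl makes no difference that can be read here. Within the data shown here, nothing measured so far explains the drop.

The swap alters two things at once, the point of attachment on the thiophene and the added methylsulfanyl group, so the compounds shown cannot say which one matters. As far as these compounds go, a plain thiophen-2-yl, or a methoxy group in place of methylsulfanyl, would help separate the two, and whether ethyl matters alongside thiophen-3-yl also remains open.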